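A few compounds are considered here, and "the series" means these few. Any claim that something is new, unique, unknown or untested is made for them only; others in the source may bear on it.

Measured in a functional assay on HEL cells (Homo sapiens) for cytotoxicity (on this read-out higher numbers stand for lower toxicity in this test and lower numbers for higher toxicity in this test), each value a limit:
- Compound 1 `CCCCC#Cc1cc2cn([C@@H]3O[C@H](CO)[C@@H](O)[C@@H]3O)c(=O)nc2o1`: > 144000 nM
- Compound 2 `CCCCCCC#Cc1cc2cn([C@@H]3O[C@H](CO)[C@@H](O)[C@@H]3O)c(=O)nc2o1`: > 53000 nM
- Compound 3 `CCCCCCC#Cc1cc2cn(C)c(=O)nc2o1`: > 194000 nM

Compound 2 has only a limit, > 53000 nM, and no number. Compound 4 `CCCCCCCCC#Cc1cc2cn([C@@H]3O[C@H](CO)[C@@H](O)[C@@H]3O)c(=O)nc2o1` differs from compound 2 as follows: ethyl in place of hydrogen on a saturated chain carbon, six bonds along the chain from a triple-bonded carbon. The closest measured change of the same kind is a step that the two limits leave unreadable from compound 1 to compound 2. The other measured change is a step that the two limits leave unreadable from compound 2 to compound 3. Neither gives a size to carry over, so no step beyond the scatter is expected in this assay, and this expectation has little support. The expected change is an at least 1.0-fold lower number from compound 2 to compound 4 (0.02 log units; that floor lies within the scatter). For compound 4 the estimated value is 50000 nM, with an expected range of 15000 nM to 125000 nM.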

Compound 4, half-maximal cytotoxic concentration: > 124000 nM
Compound 4 was reported as a limit; the forecaster's own chance of this, stated with the estimate: 65%; at least 2.4-fold (0.39 log units) between middle value and limit.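

In this assay, compound 1, compound 2 and compound 4 are all reported only as limits, so neither step to compound 4 can be read. The compounds shown leave open whether chain length changes the half-maximal cytotoxic concentration at all.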